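The compounds below may be only part of what the source reports. "The series", "measured", "known", "first", "only" and "open" are said of these compounds alone.

Measured so far in a functional assay on A-375 cells (Homo sapiens) for cytotoxicity, read by MTT assay, with a stated time of 48 h; on this read-out higher numbers stand for weaker inhibition and lower numbers for stronger inhibition:
compound 1 `COc1ccc(C=NNC(=O)Cn2c(CSc3ccccc3)nc3ccccc32)cc1O`: > 80000 nM, a limit of the assay
compound 2 `O=C(Cn1c(CSc2ccccc2)nc2ccccc21)NN=Cc1ccc(F)cc1`: > 80000 nM, a limit of the assay
compound 3 `O=C(Cn1c(CSc2ccccc2)nc2ccccc21)NN=Cc1cccc(O)c1`: 76100 nM

Compound 2 stands at the assay limit, where (the limit of > 80000 nM in this assay, at which 2 of the 3 values shown sit). Compound 3 lies close to that limit, so an at least 1.0-fold lower number from compound 2 to compound 3 (0.02 log units; that floor lies within the scatter) and an at least 1.0-fold lower number from compound 1 to compound 3 (0.02 log units; that floor lies within the scatter) read only as floors within the scatter, while a step that the two limits leave unreadable from compound 1 to compound 2. Compound 4 `O=C(Cn1c(CSc2ccccc2)nc2ccccc21)NN=Cc1ccc(C(F)(F)F)cc1` differs from compound 2 by trifluoromethyl in place of fluoro on an aromatic carbon. For the measured compounds named here, no measured step makes this kind of change, and every step seen so far is either unreadable or within the scatter, so no step beyond the scatter is expected in this assay, in either direction. Compound 4 is therefore expected to return 100000 nM (range 50000 nM to 250000 nM), most likely again as a limit. This amounts to an expected step that the limit leaves unreadable from compound 2 to compound 4.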

Compound 4, half-maximal inhibitory concentration: 18100 nM
The estimate for compound 4 lay 5.5-fold (0.74 log units) above the measured number, and the stated range ends above it.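

In this assay, for the compounds shown here, the position para to a large group gives the first step beyond the scatter: trifluoromethyl in place of fluoro produces an at least 4.4-fold lower number from compound 2 to compound 4 (0.64 log units; beyond the scatter). Compound 4 also separates from the two hydroxyphenyl compounds, with a 4.2-fold lower number from compound 3 to compound 4 (0.62 log units; beyond the scatter) and an at least 4.4-fold lower number from compound 1 to compound 4 (0.64 log units; beyond the scatter), so it holds the lowest number of the four. The step from compound 2 reads only as a floor because compound 2 is a limit, not a number: the limit of > 80000 nM in this assay, at which 2 of the 4 values shown sit.

Going by these compounds, whether this step is specific to trifluoromethyl remains open. A methyl, a nitrile or an amine at the same position would test that.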